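This account rests on a few compounds, and the source may have more. Where it says the series, first, only, none or still open, it means among the compounds named here.

Measured compounds: compound 1 `O=C(Nc1cccc(F)c1)N[C@H]1CC[C@H](Oc2ccc(F)cc2)CC1` with 8300 nM in a functional assay on CRL2813 cells (Homo sapiens) for cytotoxicity, read by sulforhodamine B assay, with a stated time of 5 days; on this read-out lower numbers stand for stronger inhibition and higher numbers for weaker inhibition; compound 2 `O=C(Nc1ccccc1F)N[C@H]1CC[C@H](Oc2ccc(F)cc2)CC1` with 17500 nM in this assay.

Within the data shown here, compound 2 stands highest of the two numbers in this assay; the only measured step, a 2.1-fold higher number from compound 1 to compound 2 (0.32 log units; beyond the scatter), moves the fluoro on the phenyl that sits on the urea nitrogen. Compound 3 `Cc1ccccc1NC(=O)N[C@H]1CC[C@H](Oc2ccc(F)cc2)CC1` differs from compound 2 by methyl in place of fluoro on an aromatic carbon. Among the measured compounds shown here, no measured step swaps a fluoro for a methyl, so nothing bears directly on this change. Compound 3 is therefore expected to give about 15000 nM in this assay, within 6000 nM to 40000 nM, which is an expected step of a 1.2-fold lower number from compound 2 to compound 3 (0.07 log units; within the scatter), not beyond the scatter.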

Compound 3, half-maximal inhibitory concentration: > 20000 nM
Compound 3: a limit, no number; the forecaster's own chance of this, stated with the estimate: 10%; middle value at least 1.3-fold (0.12 log units) away from the limit.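

In this assay the reading for compound 3 is a limit and not a number: the limit of > 20000 nM in this assay, at which 1 of the 3 values shown sits. With methyl in place of fluoro on this aromatic carbon, the result is an at least 1.1-fold higher number from compound 2 to compound 3 (0.05 log units; that floor lies within the scatter), so this floor does not by itself separate the two groups at this position. With 2-methylphenyl in place of 3-fluorophenyl, the result is an at least 2.4-fold higher number from compound 1 to compound 3 (0.38 log units; beyond the scatter), a step whose floor lies beyond the scatter.

On these data alone, the actual number for compound 3 remains open, and so does the size of the change from fluoro to methyl. As far as these compounds go, what a methoxy group or a chlorine on this aromatic carbon would give also remains open.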